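The source may report more compounds than this note shows. Statements on the series, on what has been measured and on what is new or still open speak of the compounds shown alone.

Among the compounds with values here, compound 2 `COc1ccc(Cl)cc1S(=O)(=O)Nc1cncc(C(=O)O)c1` gives 134 nM in an assay on isolated protein for inhibition of alkaline phosphatase, tissue-nonspecific isozyme (Homo sapiens) (on this read-out lower numbers stand for stronger inhibition and higher numbers for weaker inhibition), the highest of the two numbers measured so far. Its nearest neighbour is compound 1 `COc1ccc(Cl)cc1S(=O)(=O)Nc1cncc(C(N)=O)c1`, which gives 16 nM in this assay; the step of an 8.4-fold higher number from compound 1 to compound 2 (0.92 log units; beyond the scatter) was measured beyond the scatter. Compound 3 `COc1ccc(Cl)cc1S(=O)(=O)Nc1cncc(C(=O)N2CCN(C)CC2)c1` has not yet been measured in this assay. It differs from compound 2 by 4-methylpiperazin-1-yl in place of hydroxy on a carbonyl carbon, so the carboxylic acid of compound 2 becomes an amide again, though one without an amide hydrogen. Within the data shown here, the only measured step that bears on this is from compound 1 to compound 2, where replacing the amide by an acid raised the number; reversing that direction suggests a lower number for compound 3, but the new amide carries a large ring rather than two hydrogens, so only part of the gain is expected. Compound 3 is therefore estimated at 40 nM, between 10 nM and 200 nM, an expected step of a 3.4-fold lower number from compound 2 to compound 3 (0.53 log units; beyond the scatter).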

Compound 3, half-maximal inhibitory concentration: 671 nM
Estimate against measurement, compound 3: 17-fold (1.22 log units) below; the measured number lies above the stated range.
By their numbers in this assay, from the lowest: compound 1; then compound 2; then compound 3.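

Turning the acid back into an amide does not by itself restore strong inhibition in this assay: placing 4-methylpiperazin-1-yl on the carbonyl carbon gives a 5.0-fold higher number from compound 2 to compound 3 (0.70 log units; beyond the scatter), which puts this amide behind even the acid. Against the amide bearing a plain amino group the change is much larger, a 42-fold higher number from compound 1 to compound 3 (1.62 log units; beyond the scatter), so what is attached to this carbonyl carbon matters, not merely the presence of an amide. Nothing shown here gives a reason for this loss.

These compounds cannot tell whether the loss goes with the ring as a whole or with the missing amide hydrogen, since 4-methylpiperazin-1-yl differs from amino in several ways at once. Methylamino and dimethylamino on the same carbonyl carbon would pull those two apart, and whether any group there can give a lower number than compound 1 stays open.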